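Pyridinyl isomer swap in the permeability series

The compounds below may be only part of what the source reports. "The series", "measured", "known", "first", "only" and "open" are said of these compounds alone.

- compound 1 `Cn1cc(C(=O)Nc2ccc(-c3ccccc3)c(C(F)(F)F)c2)c(=O)c2ccccc21`: 1.2 10^-6 cm/s
- compound 2 `Cn1cc(C(=O)Nc2ccc(-c3ccncc3)c(C(F)(F)F)c2)c(=O)c2ccccc21`: 15 10^-6 cm/s
- compound 3 `Cn1cc(C(=O)Nc2ccc(-c3ccccn3)c(C(F)(F)F)c2)c(=O)c2ccccc21`: not yet measured

In an ADME assay on LLC-PK1 cells (Sus scrofa) for permeability (on this read-out higher numbers stand for higher permeability and lower numbers for lower permeability), compound 2 holds the higher of the two numbers, at 15 10^-6 cm/s. The next change is pyridin-2-yl in place of pyridin-4-yl on an aromatic carbon, ortho to a trifluoromethyl group. Within the data shown here, only one measured step bears on it: a 13-fold higher number from compound 1 to compound 2 (1.10 log units; beyond the scatter), a large step made by pyridin-4-yl replacing phenyl. Compound 3 keeps a pyridinyl group, so its number is expected to stay nearer to compound 2 than to compound 1, which gave 1.2 10^-6 cm/s. Among the measured compounds shown here, no measured step shows what moving the point of attachment does, so the uncertainty is wide. The expected change is modest and downward, a 1.9-fold lower number from compound 2 to compound 3 (0.27 log units; within the scatter). For compound 3 the estimated value is 8 10^-6 cm/s, with an expected range of 2.5 10^-6 cm/s to 20 10^-6 cm/s.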

Compound 3, apparent permeability in the LLC-PK1 assay: 11 10^-6 cm/s
Compound 3: the middle estimate sits 1.4-fold (0.14 log units) below what was measured, and the stated range covers the measured number.
By their numbers in the LLC-PK1 assay, from the lowest: compound 1; then compounds 3 and 2 (each within the scatter of the next).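

In the LLC-PK1 assay the point of attachment of the pyridine ring makes little difference at this position, ortho to a trifluoromethyl group, with a 1.4-fold lower number from compound 2 to compound 3 (0.13 log units; within the scatter), and pyridin-2-yl keeps most of the gap to phenyl, with a 9.2-fold higher number from compound 1 to compound 3 (0.96 log units; beyond the scatter). The same change does separate the two isomers in a physicochemical assay for solubility, in phosphate buffer, at pH 7.4 (on this read-out lower numbers stand for lower solubility and higher numbers for higher solubility), with an at least 7.9-fold lower number from compound 2 to compound 3 (0.89 log units; beyond the scatter), so a swap that is silent on one read-out is not silent on the other. In the physicochemical assay compound 2 gives 7.9 ug/mL. In the physicochemical assay compound 3 gives < 1 ug/mL, which is a limit of the assay, so the true size of the step stays unknown: the limit of < 1 ug/mL in the physicochemical assay, at which 1 of the 2 values shown sits.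

Going by these compounds, it remains open how pyridin-3-yl, or a pyridine ring carrying an amine, would read on both assays at this position. Also open, on these data alone, is whether the same split between the two read-outs would appear with a nitrile in place of the trifluoromethyl group.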